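This account rests on a few compounds, and the source may have more. Where it says the series, first, only, none or still open, it means among the compounds named here.

Measured compounds:
compound 1 `COc1cc(-c2nc3cc(/C=C4\SC(=O)NC4=O)ccc3[nH]2)cc(OC)c1OC`, 3570 nM
compound 2 `COc1ccc(-c2nc3cc(/C=C4\SC(=O)NC4=O)ccc3[nH]2)cc1OC`, 570 nM
compound 3 `COc1cc(CN2C(=O)S/C(=C\c3ccc4[nH]c(-c5cc(OC)c(OC)c(OC)c5)nc4c3)C2=O)cc(OC)c1OC`, 530 nM

All three were tested in a functional assay on A549 cells (Homo sapiens) for inhibition, read by MTT assay, with a stated time of 48 h; on this read-out lower numbers stand for stronger inhibition and higher numbers for weaker inhibition. Compound 1 carries a 3,4,5-trimethoxyphenyl group on its core and gives 3570 nM. Compound 2 differs from compound 1 by the change (hydrogen in place of methoxy on an aromatic carbon), and this single change produced a 6.3-fold lower number from compound 1 to compound 2 (0.80 log units; beyond the scatter). Compound 3 shares the trimethoxyphenyl group of compound 1 but differs from it in the other part of the molecule; the difference between the two cores is not broken down here, and what can be said is that compound 3 gives 530 nM against the value of compound 1, a lower number beyond the scatter, while compound 3 and compound 2 lie within the scatter of each other.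

Compound 4 `COc1ccc(-c2nc3cc(/C=C4\SC(=O)N(Cc5cc(OC)c(OC)c(OC)c5)C4=O)ccc3[nH]2)cc1OC` has not yet been measured in this assay. Among the measured compounds shown here, it is related to compound 3 by the change (hydrogen in place of methoxy on an aromatic carbon), which is the same change as the one from compound 1 to compound 2, with the same surroundings. The earlier instance of this change gave a modest step to a lower number. Since compound 3 already stands at a lower number than compound 1, the step is expected to be smaller here, and the estimate for compound 4 is a step of a 2.7-fold lower number from compound 3 to compound 4 (0.42 log units; beyond the scatter) in this assay. Compound 4 is therefore expected to give about 200 nM, with the likely range running from 60 nM to 700 nM.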

Compound 4, half-maximal inhibitory concentration: 130 nM
Compound 4: middle estimate off by 1.5-fold (0.19 log units), on the high side; low and high end bracket the measured number.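

In this assay, replacing 3,4,5-trimethoxyphenyl with 3,4-dimethoxyphenyl on the core of compound 3 gave a 4.1-fold lower number from compound 3 to compound 4 (0.61 log units; beyond the scatter), so the change that lowered the number on the core of compound 1 lowered it here as well. The two steps point the same way, and their sizes do not differ beyond what repeated measurements allow: the same change on two cores in this assay, a 6.3-fold lower number (0.80 log units; beyond the scatter) from compound 1 to compound 2 and a 4.1-fold lower number (0.61 log units; beyond the scatter) from compound 3 to compound 4, 1.5-fold (0.19 log units) apart, within the scatter of two such steps. This shows that the loss of this one methoxy group carried over between these two cores in this cell assay, but two pairs cannot show that it would carry over to any further core or to another cell line, and they do not explain why the number falls.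

The compounds shown leave open whether a hydroxy group, a fluorine atom or an amine in place of the departing methoxy group would give a step of similar size, and whether losing either of the two remaining methoxy groups would lower the number further. They also leave open how the step would behave if a longer chain or a carboxylic acid replaced the substituent that compound 3 and compound 4 carry on the shared core.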